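Extending the acyl group of compound 1

The compounds below may be only part of what the source reports. "The series", "measured", "known", "first", "only" and "open" are said of these compounds alone.

Working notes on the series. Compound 1 `CC(=O)Nc1ccn([C@H]2CC[C@H](O)[C@@H](C)O2)c(=O)n1` carries an acetyl group on the amide nitrogen of the shared core. In a functional assay on HCT-116 cells (Homo sapiens) for cytotoxicity, read by sulforhodamine B assay, with a stated time of 24 h (on this read-out lower numbers stand for stronger inhibition and higher numbers for weaker inhibition), compound 1 gives > 20000 nM, which is a limit of the assay and not a number. Compound 1 therefore sits at the limit of > 20000 nM in this assay, at which 2 of the 3 values shown sit. Compound 2 `CC(C)/C=C/C(=O)Nc1ccn([C@H]2CC[C@H](O[C@H]3O[C@H](C)[C@@H](N(C)C)[C@H](O)[C@H]3O)[C@@H](C)O2)c(=O)n1` carries the same unsaturated acyl group as the unmeasured target together with a further substituent elsewhere; in this assay compound 2 gives 780 nM. Compound 3 `CC(C)=CC(=O)Nc1ccn([C@H]2C[C@@H](O)[C@H](O)[C@@H](C)O2)c(=O)n1` bears a related branched unsaturated acyl group on a differently substituted remainder. In this assay compound 3 gives > 20000 nM, again a limit and not a number. Compound 4 `CC(C)/C=C/C(=O)Nc1ccn([C@H]2CC[C@H](O)[C@@H](C)O2)c(=O)n1` is the unmeasured member and differs from compound 1 by 3-methylbut-1-en-1-yl in place of methyl on a carbonyl carbon. Within the data shown here, no step between measured compounds is available for this change. Compound 3 already holds an unsaturated acyl group and still only reaches > 20000 nM, a limit. On that basis compound 4 is expected at 15000 nM, with a range from 4000 nM to 50000 nM. The step of an at least 1.3-fold lower number from compound 1 to compound 4 (0.12 log units; that floor lies within the scatter) is expected to stay within the scatter, or at most be modest toward stronger inhibition.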

Compound 4, half-maximal inhibitory concentration: > 20000 nM
Compound 4 ended at the assay's limit; the forecaster's own chance of this, stated with the estimate: 60%; at least 1.3-fold (0.12 log units) between middle value and limit.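

Compound 4 ends at a limit of the assay and not a number, as does compound 1, so no step can be read from compound 1 to compound 4: the limit of > 20000 nM in this assay, at which 3 of the 4 values shown sit.

The compounds shown leave open whether 3-methylbut-1-en-1-yl in place of methyl on a carbonyl carbon changes the read-out at all.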